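Thiophen-2-yl Replaces the Dichlorophenyl on the Ring Carbon

The source may hold more compounds than are shown below. What is called first, only, known or untested is meant among the compounds shown, and "the series" means these compounds.

Compound 3 `N#CC1=C(N)N(c2ccc(S(N)(=O)=O)cc2)C2=C(C(=O)CCC2)C1c1ccc(Cl)cc1Cl` carries a 2,4-dichlorophenyl on a saturated ring carbon of the shared core. Among the measured compounds shown here, in a functional assay on Ehrlich cells (Mus musculus) for antiproliferative activity, read by trypan blue exclusion, with a stated time of 2 h, tested at 50 ug/mL (a lower number here means a weaker effect, a higher number a stronger effect of the compound at the concentration tested), compound 3 gives 65%, the second highest of the three numbers measured so far. Compound 1 `N#CC1=C(N)N(c2ccc(S(N)(=O)=O)cc2)C2=C(C(=O)CCC2)C1c1ccc(O)cc1`, with a 4-hydroxyphenyl at the same place, gives 100%, and compound 2 `N#CC1=C(N)N(c2ccc(S(N)(=O)=O)cc2)C2=C(C(=O)CCC2)C1/C=C/c1ccccc1`, with a 2-phenylethenyl there, gives 40%. Both steps into compound 3 are beyond the scatter: a number 35 percentage points lower from compound 1 to compound 3 (beyond the scatter), while a number 25 percentage points higher from compound 2 to compound 3 (beyond the scatter). Compound 4 `N#CC1=C(N)N(c2ccc(S(N)(=O)=O)cc2)C2=C(C(=O)CCC2)C1c1cccs1` differs from compound 3 by thiophen-2-yl in place of 2,4-dichlorophenyl on a saturated ring carbon. For the measured compounds named here, no measured step exchanges an aryl group for a thiophen-2-yl, so the direction of this change cannot be read from the three values; the groups so far tried at this carbon gave widely spread numbers without a trend that covers a five-membered heteroaromatic ring. Compound 4 is therefore expected to stay close to compound 3, with a number 5 percentage points lower from compound 3 to compound 4 (within the scatter) estimated to lie within the scatter. Compound 4 is estimated at 60%, in a range from 35% to 90%.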

Compound 4, a percentage reported as activity, at one concentration (the size of the read-out at that concentration, not a potency): 88%
Estimate against measurement, compound 4: 28 percentage points below; the measured number falls inside the stated range.
By their numbers in this assay, from the lowest: compound 2; then compound 3; then compound 4; then compound 1.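

In this assay the thiophen-2-yl, a five-membered aromatic ring with 1 hetero atom, gives a number 23 percentage points higher from compound 3 to compound 4 (beyond the scatter) and a number 48 percentage points higher from compound 2 to compound 4 (beyond the scatter), which shows that the saturated ring carbon of the shared core accepts a ring other than a six-membered aromatic ring of carbon only and still keeps a high number. It does not match the 4-hydroxyphenyl, however, with a number 12 percentage points lower from compound 1 to compound 4 (beyond the scatter), so compound 1 remains the highest of the four, its steps to all the others lying beyond the scatter. Nothing available here explains these differences.

As far as these compounds go, it remains open how a furan-2-yl, a thiophen-3-yl or a pyridin-3-yl would compare at this carbon. From the compounds shown here alone, it is equally open whether a 4-methoxyphenyl would keep the number of compound 1, and whether the order of the four would hold at other concentrations.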